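The compounds below may be only part of what the source reports. "The series", "measured", "known", "first", "only" and "open" are said of these compounds alone.

Measured in a physicochemical assay for solubility, with a stated time of 3 days, at pH 7; a higher number here means a more soluble compound, a lower number a less soluble compound:
compound 1 `NC(=O)c1ccc2[nH]c(-c3ccc(OCCCO)cc3)nc2c1`: 7000 nM
compound 2 `NC(=O)c1ccc2[nH]c(-c3ccc(OC4CCCNC4)cc3)nc2c1`: > 400000 nM, a limit
compound 3 `CN1CCC(Oc2ccc(-c3nc4cc(C(N)=O)ccc4[nH]3)cc2)CC1`: > 400000 nM, a limit

Compound 2 stands at the limit of > 400000 nM in this assay, at which 2 of the 3 values shown sit. Compound 4 `NC(=O)c1ccc2[nH]c(-c3ccc(OCC4CCNCC4)cc3)nc2c1` has not yet been measured, and its change from compound 2 is (piperidin-4-yl)methyl in place of piperidin-3-yl on an oxygen on an aromatic ring. Both groups hold one six-membered non-aromatic ring with 1 hetero atom. Going by the values given here, two measured steps bear on this change: an at least 57-fold higher number from compound 1 to compound 2 (1.75 log units; beyond the scatter), and an at least 57-fold higher number from compound 1 to compound 3 (1.75 log units; beyond the scatter). Both are large, and each replaces 3-hydroxypropyl with a group holding such a ring. The exchange of one ring group for another gives a step that the two limits leave unreadable from compound 2 to compound 3. Compound 4 keeps such a ring, so no step beyond the scatter is expected. The estimated step is a number no higher from compound 2 to compound 4 (the limit leaves the size open). For compound 4 the expected value is 400000 nM. The estimated range for compound 4 runs from 150000 nM to 600000 nM.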

Compound 4, solubility: > 400000 nM
Compound 4: a limit, no number (the forecaster's own chance of this, stated with the estimate: 70%); the middle value sits exactly at the limit.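

In this assay, (piperidin-4-yl)methyl gives an at least 57-fold higher number from compound 1 to compound 4 (1.75 log units; beyond the scatter), so the large step is not confined to the two ring groups measured earlier and also appears with (piperidin-4-yl)methoxy in place of (piperidin-3-yl)oxy. Compound 4 gives only a limit, as compound 2 and compound 3 do: the limit of > 400000 nM in this assay, at which 3 of the 4 values shown sit. The steps from compound 2 to compound 4 and from compound 3 to compound 4 therefore cannot be read. The compounds shown leave open how these three ring groups rank against each other. They also leave open whether a ring without nitrogen, such as cyclohexyl, or an open-chain amine, such as 3-aminopropyl, would give a step of the same size from compound 1.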